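Filling an open ring position with a bicyclic aromatic group

A few compounds are considered here, and "the series" means these few. Any claim that something is new, unique, unknown or untested is made for them only; others in the source may bear on it.

Measured so far:
Compound 1 `CCOC(=O)c1cnc(NN2C(=O)CCC2=O)nc1C(F)(F)F` gives 1600 nM in a functional assay on Jurkat cells (Homo sapiens) for inhibition; a higher number here means a weaker inhibitor, a lower number a stronger inhibitor.
Compound 2 `CCOC(=O)c1cnc(NN2C(=O)C(C)=C(C)C2=O)nc1C(F)(F)F` gives 3900 nM in this assay.
Compound 3 `CCOC(=O)c1cnc(NN2C(=O)C=C(C)C2=O)nc1` gives 13000 nM in this assay.

Compound 3 stands at the highest of the three numbers; its gaps to compound 2 and to compound 1 both lie beyond the scatter, so it is the weakest inhibitor of the set. Compound 4 `CCOC(=O)c1cnc(NN2C(=O)C=C(C)C2=O)nc1-c1cc2ccccc2s1` is not yet measured. It differs from compound 3 in one place: 1-benzothiophen-2-yl in place of hydrogen on an aromatic carbon. Within the data shown here, no step between measured compounds matches this change. Compound 1 and compound 2 carry a group at that same position, and both give lower numbers than compound 3, but they differ from it elsewhere too, so the size of the step is uncertain. A moderate improvement is expected, a 4.3-fold lower number from compound 3 to compound 4 (0.64 log units; beyond the scatter), giving an estimated 3000 nM for compound 4, within 500 nM to 20000 nM.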

Compound 4, half-maximal inhibitory concentration: 800 nM
Compound 4: middle estimate off by 3.8-fold (0.57 log units), on the high side; measured number inside the range.
By their numbers in this assay, from the lowest: compounds 4 and 1 (each within the scatter of the next); then compound 2; then compound 3.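

Swapping hydrogen for 1-benzothiophen-2-yl on the aromatic carbon next to the ring nitrogen gives a 16-fold lower number from compound 3 to compound 4 (1.21 log units; beyond the scatter) in this assay and is the first clean reading of this position. The position therefore accepts a group of 9 heavy atoms, and that group brings a large gain over hydrogen in this pair. No measurement shown explains why the number falls.

On these data alone, whether the gain needs both aromatic rings or the sulfur remains open. A phenyl or a thiophen-2-yl group at this position would help separate these possibilities.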